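The source may report more compounds than this note shows. Statements on the series, on what has been measured and on what is new or still open speak of the compounds shown alone.

Among the measured compounds shown here, compound 2 `CCCCCOC(=O)/C=C/c1ccc(C(C)C)cc1` gives 29% in a functional assay on the whole organism for inhibition, with Brassica rapa subsp. chinensis as the target, with a stated time of 3 days, tested at 100 ppm (on this read-out lower numbers stand for less inhibition of growth and higher numbers for more inhibition of growth at the one concentration tested), the highest of the two numbers so far; compound 1 `CC(C)OC(=O)/C=C/c1ccc(C(C)C)cc1` gives 18%. For the measured compounds named here, the one measured step, a number 11 percentage points higher from compound 1 to compound 2 (beyond the scatter), went with a longer chain on the ester oxygen. Compound 3 `COC(=O)/C=C/c1ccc(C(C)C)cc1` goes the other way: hydrogen in place of butyl on a saturated chain carbon bound to an oxygen next to a carbonyl group. On the strength of that single step, a decrease in this assay is expected for compound 3, the step being estimated as a number 12 percentage points lower from compound 2 to compound 3 (beyond the scatter) because a number 11 percentage points higher from compound 1 to compound 2 (beyond the scatter) pointed upward with the longer chain. The value of compound 3 is estimated at 17%, within a range of 5% to 30%.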

Compound 3, percent growth inhibition at one concentration: 38%
Compound 3: the middle estimate sits 21 percentage points below what was measured; the whole stated range lies below it.
By their numbers in this assay, from the lowest: compound 1; then compounds 2 and 3 (each within the scatter of the next).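

In this assay hydrogen in place of butyl on a saturated chain carbon bound to an oxygen next to a carbonyl group gives a number 9 percentage points higher from compound 2 to compound 3 (within the scatter) and so shows no loss on going from pentyl to methyl, which means that a longer chain at this place does not by itself go with more inhibition. Methyl in place of isopropyl gives a number 20 percentage points higher from compound 1 to compound 3 (beyond the scatter) and leaves compound 1 as the one that stands apart from the other two. Nothing at hand explains this. On these data alone, whether the isopropyl result reflects branching stays open, since it rests on compound 1 alone. As far as these compounds go, how an ethyl or octyl chain, or a free carboxylic acid in place of the ester, would read also remains open.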